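The source may report more compounds than this note shows. Statements on the series, on what has been measured and on what is new or still open speak of the compounds shown alone.

The study concerns three compounds built on a shared core carrying a nitro-substituted bicyclic portion and a piperidine-fused pyridine. Compound 1 `C[C@]1(CN2CCc3nc(N4CCC(F)(F)CC4)ccc3C2)Cn2cc([N+](=O)[O-])nc2O1` carries a 4,4-difluoropiperidinyl group on that pyridine; in an ADME assay on Vero cells (Chlorocebus sabaeus) for cytotoxicity, read by MTT assay, with a stated time of 72 h (a lower number here means that less compound is tolerated, a higher number that more compound is tolerated), compound 1 has "not determined" (no result reported). Compound 2 `C[C@]1(CN2CCc3nc(-c4ccccc4F)ccc3C2)Cn2cc([N+](=O)[O-])nc2O1` instead carries a 2-fluorophenyl group at the same position. In this assay compound 2 gives only a limit, > 32 ug/mL, and no single number. Within the data shown here, this is the limit of > 32 ug/mL in this assay, at which 1 of the 2 values shown sits, so compound 2 stands at the upper edge of what the method reports, with no measured step to any other compound to set a scale.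

Compound 3 `C[C@]1(CN2CCc3nc(-c4ccc(C(F)(F)F)cc4)ccc3C2)Cn2cc([N+](=O)[O-])nc2O1` is the next step from compound 2: 4-(trifluoromethyl)phenyl in place of 2-fluorophenyl on an aromatic carbon, next to the ring nitrogen, meta and para to a fused ring. Among the measured compounds shown here, with no measured step to draw on, the expected change from compound 2 to compound 3 in this assay is estimated as a number no higher from compound 2 to compound 3 (the limit leaves the size open), essentially none beyond the scatter. Compound 3 is therefore expected to give about 32 ug/mL, within a range of 16 ug/mL to 64 ug/mL, most likely again reported as a limit.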

Compound 3, half-maximal cytotoxic concentration: > 32 ug/mL
Compound 3 ended at the assay's limit; the forecaster's own chance of this, stated with the estimate: 60%; the middle value sits exactly at the limit.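

Compound 2 and compound 3 both end at a limit in this assay, so no step between them can be read: the limit of > 32 ug/mL in this assay, at which 2 of the 3 values shown sit.

The compounds shown leave open where the half-maximal cytotoxic concentration of either compound actually lies, and whether 4-(trifluoromethyl)phenyl in place of 2-fluorophenyl changes it at all.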